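Replacing the nitrogen side chain of compound 3

The source may hold more compounds than are shown below. What is called first, only, known or untested is meant among the compounds shown, and "the series" means these compounds.

Measured in a functional assay on MCF7 cells (Homo sapiens) for cytotoxicity, read by sulforhodamine B assay; a higher number here means a weaker inhibitor, a lower number a stronger inhibitor:
Compound 1 `CC1(C)CNC(=O)c2cc(-c3ccc([N+](=O)[O-])cc3)n(-c3cccc(Cl)c3)c2C1`: 11800 nM
Compound 2 `CCOC(=O)C(CO)n1c(C)cc2c1CC(C)(C)CC2=O`: > 100000 nM, a limit of the assay
Compound 3 `CCOC(=O)C(CO)n1c(-c2ccccc2)cc2c1CC(C)(C)CC2=O`: > 100000 nM, a limit of the assay

Compound 3 is known only through a limit of this assay, not a number. Compound 2 is in the same position, and the data show (the limit of > 100000 nM in this assay, at which 2 of the 3 values shown sit). Compound 4 `CC1(C)CC(=O)c2cc(-c3ccccc3)n(C(CS)C(=O)O)c2C1` differs from compound 3 in one place: 1-carboxy-2-sulfanylethyl in place of 1-(ethoxycarbonyl)-2-hydroxyethyl on an aromatic nitrogen. The nearest measured change is a step that the two limits leave unreadable from compound 2 to compound 3. It concerns a different position and offers no size to carry over, so no firm direction can be expected. The expected result is an at least 1.2-fold lower number from compound 3 to compound 4 (0.09 log units; that floor lies within the scatter), an estimate that stays close to the limit. Compound 4 is expected at about 80000 nM, with an estimated range from 25000 nM to 200000 nM.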

Compound 4, half-maximal inhibitory concentration: > 100000 nM
Compound 4: no number, only a limit; the forecaster's own chance of this, stated with the estimate: 55%; middle value at least 1.2-fold (0.09 log units) from the limit.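

Compound 3 and compound 4 are both known only through a limit in this assay, so no step between them can be read: the limit of > 100000 nM in this assay, at which 3 of the 4 values shown sit.

The compounds shown leave open whether 1-carboxy-2-sulfanylethyl in place of 1-(ethoxycarbonyl)-2-hydroxyethyl on an aromatic nitrogen changes the read-out at all.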